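A few compounds are considered here, and "the series" means these few. Any claim that something is new, unique, unknown or untested is made for them only; others in the source may bear on it.

Measured compounds:
compound 1 `CC(C)N1CCN(Cc2csc(N)c2C(=O)c2ccc(Cl)cc2)CC1`: 0%
compound 2 `Nc1scc(CN2CCN(c3ccc(Cl)cc3Cl)CC2)c1C(=O)c1ccc(Cl)cc1`: 0%
compound 3 `Nc1scc(CN2CCN(c3c(F)cc(F)cc3F)CC2)c1C(=O)c1ccc(Cl)cc1`: 0%

In an assay on CHO cells for displacement of a labelled ligand from adenosine receptor A1 (Homo sapiens), read by scintillation counting, with a stated time of 120 min, tested at 10 uM (on this read-out higher numbers stand for more inhibition at the one concentration tested (going by the name of the read-out) and lower numbers for less inhibition), compound 3 gives 0%. It is level with compound 1 and compound 2 at the digits shown, within the scatter of the method. The three measured steps all alter the group on the ring nitrogen: no change at the digits printed from compound 1 to compound 2 (within the scatter), no change at the digits printed from compound 1 to compound 3 (within the scatter) and no change at the digits printed from compound 2 to compound 3 (within the scatter). None moves the read-out beyond the scatter.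

Compound 4 `Nc1scc(CN2CCN(CCCc3ccc(Cl)cc3)CC2)c1C(=O)c1ccc(Cl)cc1` is not yet measured. It differs from compound 3 at the same position: 3-(4-chlorophenyl)propyl in place of 2,4,6-trifluorophenyl on an amine nitrogen in a ring. Among the measured compounds shown here, since every change at that position so far has left this assay unchanged, the expected step of no change at the digits printed from compound 3 to compound 4 (within the scatter) is none beyond the scatter. Compound 4 is estimated at 0%, with a range from -10% to 15%.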

Compound 4, a percentage reported as inhibition, at one concentration (the size of the read-out at that concentration, not a potency): 0%
Beside the measured number, compound 4's estimate shows no gap at the digits printed; the measured number falls inside the stated range.
By their numbers in this assay, from the lowest: compounds 1, 2, 3 and 4 (each within the scatter of the next).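

The 3-(4-chlorophenyl)propyl group extends the range of groups on the amine nitrogen to an aryl group carried on a propyl chain, yet this assay still shows no change at the digits printed from compound 3 to compound 4 (within the scatter) and no change at the digits printed from compound 2 to compound 4 (within the scatter) as well as no change at the digits printed from compound 1 to compound 4 (within the scatter). Neither this chain nor the earlier isopropyl and directly attached aryl groups lifts the read-out beyond the scatter. No supporting data bear on this result.

As far as these compounds go, whether a carboxylic acid or a primary amine at the end of a longer chain on that nitrogen would register remains open. Changes elsewhere on the shared core also remain untested by these compounds.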